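The source may hold more compounds than are shown below. What is called first, only, known or untested is meant among the compounds shown, and "the series" means these compounds.

For the measured compounds named here, compound 3 `O=CCN1N=C(c2ccc3ccccc3c2)CC1c1cccc(Br)c1` gives 10900 nM in a functional assay on PC-3 cells (Homo sapiens) for cytotoxicity, read by sulforhodamine B assay, with a stated time of 48 h (on this read-out higher numbers stand for weaker inhibition and lower numbers for stronger inhibition), and stands highest of the three numbers measured so far. Compound 1 `O=CCN1N=C(c2ccc3ccccc3c2)CC1c1cccc([N+](=O)[O-])c1` gives 2980 nM in this assay, and compound 2 `COc1ccc(C2CC(c3ccc4ccccc4c3)=NN2CC=O)cc1O` gives 2040 nM. The gap is a 3.7-fold higher number from compound 1 to compound 3 (0.56 log units; beyond the scatter) and a 5.3-fold higher number from compound 2 to compound 3 (0.73 log units; beyond the scatter), both beyond the scatter, while a 1.5-fold lower number from compound 1 to compound 2 (0.16 log units; within the scatter) is within it.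

Compound 4 `O=CCN1N=C(c2ccc3ccccc3c2)CC1c1ccco1` differs from compound 3 by furan-2-yl in place of 3-bromophenyl on a saturated ring carbon. Going by the values given here, the steps that bear on this change are the two that replaced the group at this position, namely a 5.3-fold higher number from compound 2 to compound 3 (0.73 log units; beyond the scatter) and a 3.7-fold higher number from compound 1 to compound 3 (0.56 log units; beyond the scatter), both of which moved the number up beyond the scatter. Among the compounds with values here, no measured compound carries a five-membered aromatic ring at this position, so neither direction is supported directly; since compound 3 holds the highest number of the series, a move back toward the other two is as plausible as a further rise. Compound 4 is therefore expected near 6000 nM, within 1800 nM to 20000 nM, an expected step of a 1.8-fold lower number from compound 3 to compound 4 (0.26 log units; within the scatter).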

Compound 4, half-maximal inhibitory concentration: 23000 nM
For compound 4 the middle estimate is 3.8-fold (0.58 log units) below the measured one; measured number above the stated range.
By their numbers in this assay, from the lowest: compounds 2 and 1 (each within the scatter of the next); then compound 3; then compound 4.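

In this assay, the position on the saturated ring carbon tolerates less than the three phenyl compounds suggested: furan-2-yl gives a 2.1-fold higher number from compound 3 to compound 4 (0.32 log units; beyond the scatter), and the number rises further against the other two groups, with a 7.7-fold higher number from compound 1 to compound 4 (0.89 log units; beyond the scatter) and an 11-fold higher number from compound 2 to compound 4 (1.05 log units; beyond the scatter). All three steps lie beyond the scatter, so each of the three substituted phenyl groups gives a lower number than furan-2-yl, and the span at this position now reaches the large class, where the phenyl compounds alone stayed modest. No measurement at hand explains this rise.

For the compounds shown here, with only one five-membered ring at this position, the ring size and the ring oxygen cannot be told apart. Thiophen-2-yl or unsubstituted phenyl would separate them, and a phenyl ring carrying an amine or a carboxylic acid would test how far the substituent alone moves the number.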